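Replacing the amide substituent of compound 1: an expected shift

This account rests on a few compounds, and the source may have more. Where it says the series, first, only, none or still open, it means among the compounds named here.

Compound 1 `CCn1c(C(=O)NCCN)ccc1C(CC)(CC)c1ccc(OCCC(O)(CC)CC)c(C)c1` has the lowest of the two numbers measured here. In an ADME assay on L02 cells (Homo sapiens) for antiproliferative activity, read by MTT assay, with a stated time of 48 h (on this read-out higher numbers stand for weaker inhibition and lower numbers for stronger inhibition), compound 1 gives 2940 nM. For the measured compounds named here, compound 2 `CCn1c(C(=O)NC(CC(=O)O)C(=O)OC)ccc1C(CC)(CC)c1ccc(OCCC(O)(CC)CC)c(C)c1` gives 7590 nM in this assay, and the one measured step, a 2.6-fold higher number from compound 1 to compound 2 (0.41 log units; beyond the scatter), shows that a larger group on the amide-type nitrogen went with a higher number.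

Compound 3 `CCC(C)C(CO)NC(=O)c1ccc(C(CC)(CC)c2ccc(OCCC(O)(CC)CC)c(C)c2)n1CC` differs from compound 1 by 1-(hydroxymethyl)-2-methylbutyl in place of 2-aminoethyl on an amide-type nitrogen. Going by the values given here, the incoming group is larger than the outgoing one, as in the step to compound 2, but it carries a hydroxyl rather than an amino group and a carboxylic acid, so the single step offers only a loose guide. Among the compounds with values here, a modest rise, smaller than or near the one to compound 2, is expected. For compound 3 in this assay the estimate is 4500 nM, within 2000 nM to 10000 nM, meaning an expected step of a 1.5-fold higher number from compound 1 to compound 3 (0.18 log units; within the scatter).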

Compound 3, half-maximal inhibitory concentration: > 50000 nM
Compound 3 gave a limit, no number; the forecaster's own chance of this, stated with the estimate: 5%; middle value at least 11-fold (1.04 log units) away from the limit.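

Compound 3 gives a limit of the assay and not a number in this assay: the limit of > 50000 nM in this assay, at which 1 of the 3 values shown sits. The change on this amide-type nitrogen can therefore move the read-out much further than the earlier step showed, with an at least 17-fold higher number from compound 1 to compound 3 (1.23 log units; beyond the scatter), and an at least 6.5-fold higher number from compound 2 to compound 3 (0.81 log units; beyond the scatter). Group size alone does not order these compounds: the larger group went with the higher number from compound 1 to compound 2, but compound 3 goes against that pattern, since its 1-(hydroxymethyl)-2-methylbutyl group is smaller than the group in compound 2, yet its reading is the higher.

The compounds shown do not separate the roles of the hydroxyl and the branched carbon chain within 1-(hydroxymethyl)-2-methylbutyl. A 2-hydroxyethyl group, or a branched alkyl chain with no hydroxyl, would bear on that question.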